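This account rests on a few compounds, and the source may have more. Where it says the series, first, only, none or still open, it means among the compounds named here.

Compound 1 `CCCc1ccc(NC2=CC(=O)c3nc4n(c3C2=O)[C@H]2OC[C@@H](O)[C@H]2OC4)cc1` gives 4990 nM in a functional assay on HeLa cells (Homo sapiens) for inhibition, read by sulforhodamine B assay; a higher number here means a weaker inhibitor, a lower number a stronger inhibitor. Compound 2 `O=C1C=C(N2CCC2)C(=O)c2c1nc1n2[C@H]2OC[C@@H](O)[C@H]2OC1` reaches only a limit of the measurement, > 16000 nM in this assay. Compound 3 `O=C1C=C(Nc2ccc(C(F)(F)F)cc2)C(=O)c2c1nc1n2[C@H]2OC[C@@H](O)[C@H]2OC1` likewise reaches only a limit, > 8000 nM in this assay, so that of the three values shown it is one of two that are limits rather than numbers. Among the compounds with values here, the only measured step that touches the same part of the molecule, an at least 1.6-fold higher number from compound 1 to compound 3 (0.20 log units; that floor lies within the scatter), ends at a limit of > 8000 nM in this assay, at which 1 of the 3 values shown sits, and is therefore known only as a floor that itself lies within the scatter. Compound 4 `COc1cccc(NC2=CC(=O)c3nc4n(c3C2=O)[C@H]2OC[C@@H](O)[C@H]2OC4)c1` differs from compound 3 by 3-methoxyphenyl in place of 4-(trifluoromethyl)phenyl on an amine nitrogen. No measured pair changes this group in the same way, so the direction of the change cannot be read from the numbers shown. Compound 4 is therefore expected to give about 7000 nM in this assay, with a range from 2500 nM to 20000 nM. The step this estimate implies, an at least 1.1-fold lower number from compound 3 to compound 4 (0.05 log units; that floor lies within the scatter), is expected to stay within the scatter, with a real chance that compound 4 again returns only a limit.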

Compound 4, half-maximal inhibitory concentration: 4280 nM
Compound 4: middle estimate off by 1.6-fold (0.21 log units), on the high side, within the range that was stated.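

With a second real number on this amine nitrogen, 3-methoxyphenyl in place of 4-propylphenyl gives a 1.2-fold lower number from compound 1 to compound 4 (0.07 log units; within the scatter), so these two groups cannot be told apart in this assay. The exchange of azetidin-1-yl for (3-methoxyphenyl)amino on the double-bonded ring carbon gives an at least 3.7-fold lower number from compound 2 to compound 4 (0.57 log units; beyond the scatter), the first step shown that clears the scatter, although it is only a floor. Putting 3-methoxyphenyl in place of 4-(trifluoromethyl)phenyl gives an at least 1.8-fold lower number from compound 3 to compound 4 (0.27 log units; that floor lies within the scatter), which is also only a floor and fixes no size for this change.

As far as these compounds go, compound 2 and compound 3 are both limits, so their true distance from compound 4 stays open. Also open, from the compounds shown here alone, is whether a carboxylic acid or a longer chain on the phenyl group would move the number beyond the scatter from compound 1 and compound 4.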